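N-Methylation of the Bromo Sulfonamide in the Aromatase Series

A few compounds are considered here, and "the series" means these few. Any claim that something is new, unique, unknown or untested is made for them only; others in the source may bear on it.

Measured compounds:
Compound 1 `COc1ccc(COc2cc([N+](=O)[O-])ccc2N(C)S(C)(=O)=O)cc1`: 470 nM
Compound 2 `CN(c1ccc([N+](=O)[O-])cc1OCc1ccc(Cl)cc1)S(C)(=O)=O`: 2400 nM
Compound 3 `CS(=O)(=O)Nc1ccc([N+](=O)[O-])cc1OCc1ccc(Br)cc1`: 5850 nM

In an assay on SK-BR-3 cells for inhibition of Aromatase (Homo sapiens) (on this read-out higher numbers stand for weaker inhibition and lower numbers for stronger inhibition), compound 3 gives 5850 nM, the highest number of the three, beyond the scatter from both others; compound 2 is the nearest and compound 1 the furthest. The step to compound 4 `CN(c1ccc([N+](=O)[O-])cc1OCc1ccc(Br)cc1)S(C)(=O)=O` is methyl in place of hydrogen on a sulfonamide nitrogen. Among the measured compounds shown here, no measured pair in this assay separates a sulfonamide hydrogen from a methyl on that nitrogen, so no step bears on this change directly. For the measured compounds named here, the one measured step, a 5.1-fold higher number from compound 1 to compound 2 (0.71 log units; beyond the scatter), concerns the substituent on the distal ring and not the sulfonamide nitrogen. Compound 4 carries the methyl(methylsulfonyl)amino group that compounds 1 and 2 also carry, and differs from compound 2 only in bromo in place of chloro; the values of compound 2 and compound 3 show that the bromo compound lacking the methyl sits above the chloro compound bearing it. The expectation is therefore a modest move downward, a 2.3-fold lower number from compound 3 to compound 4 (0.37 log units; beyond the scatter), toward the value of compound 2. Compound 4 is estimated at 2500 nM, with a range of 900 nM to 7000 nM in this assay.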

Compound 4, half-maximal inhibitory concentration: 330 nM
Compound 4: the middle estimate sits 7.6-fold (0.88 log units) above what was measured; measured number below the stated range.
By their numbers in this assay, from the lowest: compounds 4 and 1 (each within the scatter of the next); then compound 2; then compound 3.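

In this assay, among the compounds shown here, the pair of compound 3 and compound 4 isolates the sulfonamide nitrogen and gives an 18-fold lower number from compound 3 to compound 4 (1.25 log units; beyond the scatter), the largest step, so methyl in place of hydrogen at this position matters more than the earlier compounds could show. With the methyl(methylsulfonyl)amino group held constant, the distal substituent still counts: bromo in place of chloro gives a 7.3-fold lower number from compound 2 to compound 4 (0.86 log units; beyond the scatter), whereas bromo in place of methoxy gives a 1.4-fold lower number from compound 1 to compound 4 (0.15 log units; within the scatter), leaving compound 2 apart from the other two compounds carrying that group. No data on hand explain either step.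

Hydrogen and methyl on the sulfonamide nitrogen are compared here only with the bromo substituent, so whether the step carries over to the chloro or methoxy compounds remains open. Also open, on these data alone, is how an ethyl group or a longer chain on that nitrogen would read out.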